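Chloro in place of hydrogen on compound 3

The source may hold more compounds than are shown below. What is called first, only, known or untested is meant among the compounds shown, and "the series" means these compounds.

Of the compounds shown here, three with the shared core have numbers so far in a functional assay on MDA-MB-468 cells (Homo sapiens) for inhibition, read by sulforhodamine B assay, with a stated time of 48 h (on this read-out lower numbers stand for stronger inhibition of growth and higher numbers for weaker inhibition of growth), and set the frame for this step. Compound 3 (`COc1cc(-c2nn(-c3cccc(NC(=O)c4cccc(C(F)(F)F)c4)c3)cc2-c2ccncc2)ccc1Cl`) gives 1320 nM and is level within the scatter with compound 1 (`O=C(Nc1cccc(-n2cc(-c3ccncc3)c(-c3ccc(Cl)c(O)c3)n2)c1)Nc1cccc(C(F)(F)F)c1`) at 980 nM on this measure. Compound 2 (`COc1cc(-c2nn(-c3cccc(NC(=O)Nc4cc(C(F)(F)F)cc(C(F)(F)F)c4)c3)cc2-c2ccncc2)ccc1Cl`) gives 307 nM as a number lower than that of compound 3 by more than the scatter.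

Compound 4 (`COc1cc(-c2nn(-c3cccc(NC(=O)c4ccc(Cl)c(C(F)(F)F)c4)c3)cc2-c2ccncc2)ccc1Cl`) has not yet been measured. It departs from compound 3 by one change (chloro in place of hydrogen on an aromatic carbon), with chloro in place of hydrogen on an aromatic carbon, ortho to a trifluoromethyl group and para to a large group. This turns 3-(trifluoromethyl)phenyl into 4-chloro-3-(trifluoromethyl)phenyl.

For the measured compounds named here, no measured pair differs in one place only, so no direct precedent exists for this change. Compound 2 at 307 nM carries a second trifluoromethyl group, but it differs from compound 3 in more than one place and offers only weak guidance. On that thin basis, a small step toward stronger inhibition of growth is expected in this assay for this change. The estimated change is a 1.9-fold lower number from compound 3 to compound 4 (0.28 log units; within the scatter) in that expected direction. The estimate for compound 4 is 700 nM with an expected range from 250 nM to 1800 nM on this measure.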

Compound 4, concentration for 50% growth inhibition: 3690 nM
For compound 4 the middle estimate is 5.3-fold (0.72 log units) below the measured one; the whole stated range lies below it.
By their numbers in this assay, from the lowest: compound 2; then compounds 1 and 3 (each within the scatter of the next); then compound 4.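

In this assay, chloro in place of hydrogen on this aromatic carbon, ortho to a trifluoromethyl group and para to a large group, gives a 2.8-fold higher number from compound 3 to compound 4 (0.45 log units; beyond the scatter), a modest step toward weaker inhibition of growth and beyond the scatter. For the compounds shown here, this is the first change that can be read in one place, and it shows that this position of the 3-(trifluoromethyl)phenyl group is not indifferent to substitution: adding one chlorine atom is enough to move the number. Nothing measured here bears on the reason for this step.

The compounds shown leave open whether the step belongs to chloro in particular or would also appear with fluoro, methyl, methoxy or an amine at the same carbon. They also leave open whether the same chloro for hydrogen change would move the number in the same direction on a compound carrying the urea linkage of compound 2, since this step has been read only on the background of compound 3.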